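The source may hold more compounds than are shown below. What is called first, only, known or untested is meant among the compounds shown, and "the series" means these compounds.

Measured compounds:

- compound 1 `Cn1c(COc2cccc(C(=O)O)c2)nc2ccc(Oc3ccc(F)cc3)nc21`: 1.5
- compound 2 `Cn1c(COc2cccc(C(=O)O)c2)nc2cnc(Oc3ccc(Cl)c(F)c3)cc21`: 1.4
- compound 3 `Cn1c(COc2cccc(C(=O)O)c2)nc2ccc(Oc3ccccn3)cc21`: 0.4

In a physicochemical assay for lipophilicity, read by LC-MS, in phosphate buffer, measured as octanol-water partition, with a stated time of 30 min, at pH 7.4, tested at 200 mM (a lower number here means a more polar compound, a higher number a more lipophilic compound), compound 3 holds the lowest of the three numbers. Its nearest neighbour is compound 2, whose number lies above it beyond the scatter, and compound 1 sits further up again, also beyond the scatter. Going by the values given here, no two of the three measured compounds differ in only one place, so no single counted step is available among them; the three values only show that compound 3 is set apart at the low end and that compounds 1 and 2 lie within the scatter of each other.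

The next compound, compound 4 `Cn1c(COc2cccc(C(=O)O)c2)nc2ccc(Oc3ncccc3Cl)cc21`, differs from compound 3 by chloro in place of hydrogen on an aromatic carbon, read one bond further out as pyridin-2-yl to 3-chloropyridin-2-yl.

With no measured pair of this kind in the series, the size of the step rests on the change alone. The expectation is a rise in this assay beyond the scatter, moderate rather than large. For compound 4 the estimate is 1, in the range 0.6 to 1.4, which would mean an expected step of a number 0.60 log units higher from compound 3 to compound 4 (beyond the scatter).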

Compound 4, distribution coefficient: 1.1
Beside the measured number, compound 4's estimate is 0.10 log units below it; the range from low to high includes it.
By their numbers in this assay, from the lowest: compound 3; then compounds 4, 2 and 1 (each within the scatter of the next, the first and the last beyond it).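

In this assay, chloro in place of hydrogen on an aromatic carbon, ortho to a large group and two atoms from the ring nitrogen, gives a number 0.70 log units higher from compound 3 to compound 4 (beyond the scatter). Going by these compounds alone, this is the first counted step, as the earlier compounds offered no pair differing in only one place; it shows that this single change, read as pyridin-2-yl to 3-chloropyridin-2-yl, is enough to shift the read-out, though the reading rests on one pair at one position. Nothing measured in hand accounts for the size of this step.

As far as these compounds go, whether the step belongs to chloro itself or to this particular place on the ring remains open, and methyl, methoxy or nitrile on the same carbon, along with chloro on another carbon of the same ring, would help to separate the two. Also open, from the compounds shown here alone, is whether the same change would give a step of similar size on a different core, or with an amide or a tetrazole in place of the carboxylic acid.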